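The source may report more compounds than this note shows. Statements on the series, on what has been measured and on what is new or still open speak of the compounds shown alone.

Compound 3 `O=C(OC1(C(=O)Nc2ccc([N+](=O)[O-])cc2)CCCCC1)c1ccccc1` gives 903 nM in a functional assay on MCF7 cells (Homo sapiens) for inhibition, read by MTT assay, with a stated time of 72 h (on this read-out lower numbers stand for stronger inhibition and higher numbers for weaker inhibition), the highest number of the three measured compounds. Its nearest neighbour is compound 1 `Cc1ccccc1C(=O)OC1(C(=O)Nc2ccc([N+](=O)[O-])cc2)CCCCC1`, which gives 516 nM; the step from one to the other, a 1.8-fold higher number from compound 1 to compound 3 (0.24 log units; within the scatter), lies within the scatter. Far below both stands compound 2 `O=C(OC1(C(=O)Nc2ccc([N+](=O)[O-])cc2)CCCCC1)c1ccc([N+](=O)[O-])cc1`, which gives 8.7 nM, and the steps of a 59-fold lower number from compound 1 to compound 2 (1.77 log units; beyond the scatter) and a 100-fold higher number from compound 2 to compound 3 (2.02 log units; beyond the scatter) are both large and beyond the scatter.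

Compound 4 `CC(=O)OC1(C(=O)Nc2ccc([N+](=O)[O-])cc2)CCCCC1` differs from compound 3 by methyl in place of phenyl on a carbonyl carbon. Among the compounds with values here, none of the measured steps bears directly on this change: the steps among compounds 1, 2 and 3 concern substituents on the aromatic ring of the ester, not the removal of that ring itself. Within the data shown here, the one step that leaves the ester aromatic ring bare of substituents, a 1.8-fold higher number from compound 1 to compound 3 (0.24 log units; within the scatter), was within the scatter, which suggests that changes at this part of the molecule need not be large, while the nitro group of compound 2 shows that they can be. Given this, compound 4 is expected to land close to compound 3, with the estimated step of a 1.7-fold higher number from compound 3 to compound 4 (0.22 log units; within the scatter) uncertain in direction and spanning a wide range. The estimate for compound 4 in this assay is 1500 nM, between 300 nM and 8000 nM.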

Compound 4, half-maximal inhibitory concentration: 403 nM
Estimate against measurement, compound 4: 3.7-fold (0.57 log units) above; low and high end bracket the measured number.
By their numbers in this assay, from the lowest: compound 2; then compounds 4, 1 and 3 (each within the scatter of the next, the first and the last beyond it).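

Taking the whole aromatic ring off the ester and leaving a methyl on the carbonyl carbon does not cost inhibition in this assay: the change gives a 2.2-fold lower number from compound 3 to compound 4 (0.35 log units; beyond the scatter), a modest step, so a phenyl on this carbonyl carbon is not needed for a number at this level. Within the data shown here, the methyl also cannot be told apart from the 2-methylphenyl group, since a 1.3-fold lower number from compound 1 to compound 4 (0.11 log units; within the scatter) stays within the scatter, whereas a 46-fold higher number from compound 2 to compound 4 (1.67 log units; beyond the scatter) is large, which leaves 4-nitrophenyl as the one group among the four that stands clearly apart from the others at this place. No evidence is at hand that would account for these differences.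

Still open is how a longer chain such as propyl, or a saturated ring such as cyclohexyl, would read on this carbonyl carbon, since the compounds shown carry only methyl or an aromatic ring there. On these data alone, it is also open whether the low number of compound 2 belongs to the nitro group alone, or whether a nitrile, an amine or a carboxylic acid in its place on the aromatic ring would read the same way.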